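Adding a methyl to the shorter chain of compound 1

This account rests on a few compounds, and the source may have more. Where it says the series, first, only, none or still open, it means among the compounds named here.

In a functional assay (aorta) with Rattus norvegicus as the target (a higher number here means that more compound is needed for the effect, a lower number that less compound is needed), compound 1 `CCC1(C)C=C(/C(S)=N\C)c2cc([N+](=O)[O-])ccc2O1` gives 0.182 nM, the middle of the three measured numbers. Compound 2 `CCCC1(C)C=C(/C(S)=N\C)c2cc([N+](=O)[O-])ccc2O1` gives 0.017 nM, and compound 3 `CCCCC1(C)C=C(/C(S)=N\C)c2cc([N+](=O)[O-])ccc2O1` gives 40.7 nM.

Compound 4 `CCC1(CC)C=C(/C(S)=N\C)c2cc([N+](=O)[O-])ccc2O1` keeps the core of compound 1 and differs by methyl in place of hydrogen on a saturated chain carbon bound to a saturated ring carbon, which reads as methyl to ethyl. Among the measured compounds shown here, no measured step sits at this place. The closest evidence comes from changes on the other chain: an 11-fold lower number from compound 1 to compound 2 (1.03 log units; beyond the scatter), then a 2400-fold higher number from compound 2 to compound 3 (3.38 log units; beyond the scatter), and overall a 220-fold higher number from compound 1 to compound 3 (2.35 log units; beyond the scatter). All three are large, and they do not share one direction, so they give no firm sign for the new change. In this assay, the expected result is therefore no clear step beyond the scatter, though the uncertainty is wide. The estimated step is a 1.6-fold higher number from compound 1 to compound 4 (0.22 log units; within the scatter). For compound 4 the estimate is 0.3 nM, with an expected range from 0.02 nM to 5 nM.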

Compound 4, half-maximal effective concentration: 0.372 nM
The estimate for compound 4 lay 1.2-fold (0.09 log units) below the measured number; low and high end bracket the measured number.
By their numbers in this assay, from the lowest: compound 2; then compound 1; then compound 4; then compound 3.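

In this assay, methyl in place of hydrogen on a saturated chain carbon bound to a saturated ring carbon gives a 2.0-fold higher number from compound 1 to compound 4 (0.31 log units; beyond the scatter), a modest step. On the other chain, the first added methyl went the opposite way, with an 11-fold lower number from compound 1 to compound 2 (1.03 log units; beyond the scatter), so an added methyl does not move the number in one direction across the series. Nor does the same change carry a fixed size: the same change on two cores in this assay, a 2400-fold higher number (3.38 log units; beyond the scatter) from compound 2 to compound 3 and a 2.0-fold higher number (0.31 log units; beyond the scatter) from compound 1 to compound 4, 1200-fold (3.07 log units) apart, beyond the scatter of two such steps.

As far as these compounds go, a single step at this position gives no trend, and whether a longer chain here, such as propyl in place of the ethyl of compound 4, would bring a rise as large as that seen at compound 3 remains open. From the compounds shown here alone, the effect of a hydroxyl or an amine at the end of either chain also remains open.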